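The source may hold more compounds than are shown below. What is called first, only, known or untested is meant among the compounds shown, and "the series" means these compounds.

Compound 1 `COc1cc(-c2cc(/C=C/C(C)=O)[nH]n2)cc(OC)c1OC` is the weakest of three compounds measured in a functional assay on MCF7 cells (Homo sapiens) for inhibition, read by MTT assay, with a stated time of 48 h (a higher number here means a weaker inhibitor, a lower number a stronger inhibitor), where compound 1 gives 20100 nM. Compound 2 `COc1cc(-c2cc(/C=C3\Cc4ccccc4C3=O)[nH]n2)cc(OC)c1OC` gives 4800 nM in this assay, and compound 3 `COc1cc2c(cc1OC)C(=O)/C(=C/c1cc(-c3cc(OC)c(OC)c(OC)c3)n[nH]1)C2` gives 2000 nM; both gaps to compound 1 lie beyond the scatter. Compound 4 `COc1cc(-c2cc(/C=C/C(=O)c3ccc(Cl)c(Cl)c3)[nH]n2)cc(OC)c1OC` has not yet been measured. It differs from compound 1 in one place: 3,4-dichlorophenyl in place of methyl on a carbonyl carbon. Among the measured compounds shown here, no measured pair shows this exact change, but compound 2 and compound 3 also carry a ring in place of the methyl on the carbonyl carbon and both give lower numbers than compound 1. A downward step beyond the scatter is therefore expected, a 4.0-fold lower number from compound 1 to compound 4 (0.60 log units; beyond the scatter). For compound 4 the estimate in this assay is 5000 nM, with a range from 1500 nM to 15000 nM.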

Compound 4, half-maximal inhibitory concentration: 3200 nM
Beside the measured number, compound 4's estimate is 1.6-fold (0.19 log units) above it, and the stated range covers the measured number.
By their numbers in this assay, from the lowest: compounds 3, 4 and 2 (each within the scatter of the next, the first and the last beyond it); then compound 1.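

Among the compounds shown here, measured in this assay the swap of methyl for 3,4-dichlorophenyl on a carbonyl carbon gives a 6.3-fold lower number from compound 1 to compound 4 (0.80 log units; beyond the scatter) and is the first direct reading of this change. This position therefore accepts a much larger group carrying an aromatic ring, and inhibition improves rather than being lost. No measurement shown explains this step. The compounds shown leave open whether the gain comes from the ring or from its two chlorine atoms, which an unsubstituted phenyl would help separate. From the compounds shown here alone, how an amine or a carboxylic acid on that ring would read also remains open.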